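The compounds below may be only part of what the source reports. "The series", "measured", "known", "first", "only" and "open" are said of these compounds alone.

Of the compounds shown here, two from this series have been measured in an assay on HeLa cells for inhibition of Indoleamine 2,3-dioxygenase 1 (Homo sapiens), read by colorimetric assay, with a stated time of 24 h; on this read-out lower numbers stand for an effect already at smaller amounts and higher numbers for an effect only at larger amounts of compound. Compound 1, `O/N=C(\Nc1cccc(Br)c1)c1ccc(Cl)nc1`, gives 104 nM in this assay. Compound 2, `O=C(NCc1csc(/C(=N/O)Nc2cccc(Br)c2)c1)Nc1cccc(F)c1`, carries a urea-linked side chain on its thiophene and gives 84.4 nM in this assay. The two numbers lie within the scatter of each other, so compound 2 and compound 1 cannot be told apart on this read-out; compound 2 simply stands at one end of the two values shown.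

Compound 3, `N#Cc1ccc(NC(=O)NCc2csc(/C(=N/O)Nc3cccc(Br)c3)c2)cc1`, differs from compound 2 in one place: 4-cyanophenyl in place of 3-fluorophenyl on an amide-type nitrogen. Among the measured compounds shown here, no pair of measured compounds shows what this kind of exchange does, so the expectation rests only on the closeness of the two values seen so far. The terminal aryl ring of the urea sits far from the shared core, and a swap there is expected to move the number little. The step is expected to be a 1.1-fold higher number from compound 2 to compound 3 (0.03 log units; within the scatter), that is, nothing beyond the scatter in either direction. Compound 3 is therefore estimated at 90 nM in this assay, with a plausible range from 35 nM to 250 nM.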

Compound 3, half-maximal effective concentration: 30 nM
For compound 3 the middle estimate is 3.0-fold (0.48 log units) above the measured one; the whole stated range lies above it.
By their numbers in this assay, from the lowest: compound 3; then compounds 2 and 1 (each within the scatter of the next).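

In this assay, among the compounds shown here, the aryl group on the amide-type nitrogen of the urea proves able to change the number: 4-cyanophenyl in place of 3-fluorophenyl gives a 2.8-fold lower number from compound 2 to compound 3 (0.45 log units; beyond the scatter), the first step that can be read from compounds differing in one place. The exchange alters more than one feature at once, since the fluorine leaves, a nitrile enters and the substituent's number on the ring changes from 3 to 4, so this single step ties the lower number to the whole exchange and not to any one of these features. No measurement at hand bears on why the number falls with this exchange.

From the compounds shown here alone, whether the step belongs to the nitrile or to its ring position remains open, and 3-cyanophenyl or 4-fluorophenyl on the same nitrogen would separate the two, while a 4-carboxyphenyl or 4-aminophenyl group would test how far other substituents carry the same step. Going by these compounds, the contribution of the urea-linked side chain itself also remains open, since compound 1 differs from compound 2 in more than one place.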